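The compounds below may be only part of what the source reports. "The series", "measured", "known", "first", "only" and "open" are said of these compounds alone.

Three compounds share a core and were tested in a functional assay on the whole organism with Scenedesmus acutus as the target; on this read-out lower numbers stand for stronger inhibition and higher numbers for weaker inhibition. Compound 2, `CCCOC(=O)c1cc(N2C(=O)C3=C(CCCC3)C2=O)ccc1Cl`, gives 1860 nM. Compound 1, `CCCOC(=O)c1cc(N2C(=O)C3=C(CCCC3)C2=O)c(F)cc1Cl`, gives 89.1 nM. Compound 3, `C#CCOc1cc(N2C(=O)C3=C(CCCC3)C2=O)ccc1Cl`, gives 79.4 nM. Compound 1 and compound 3 give numbers within the usual scatter of each other. Compound 1 differs from compound 2 by fluoro in place of hydrogen on an aromatic carbon, and this change made a 21-fold lower number from compound 2 to compound 1 (1.32 log units; beyond the scatter). The two cores differ by propargyloxy in place of propoxycarbonyl on an aromatic carbon, a change that made a 23-fold lower number from compound 2 to compound 3 (1.37 log units; beyond the scatter).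

Compound 4, `C#CCOc1cc(N2C(=O)C3=C(CCCC3)C2=O)c(F)cc1Cl`, has not yet been measured. It differs from compound 3 by fluoro in place of hydrogen on an aromatic carbon. For the measured compounds named here, this is the same kind of change as the one from compound 2 to compound 1, not the same: in compound 4 the fluoro stands para to a propargyloxy group, whereas in compound 1 it stands para to a propoxycarbonyl group. A step of the same direction, a 9.9-fold lower number from compound 3 to compound 4 (1.00 log units; beyond the scatter), is expected in this assay, because the earlier change gave a 21-fold lower number from compound 2 to compound 1 (1.32 log units; beyond the scatter). This rests on a single earlier instance, so a somewhat smaller step is assumed. Compound 4 is therefore estimated at 8 nM, expected between 2.5 nM and 30 nM.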

Compound 4, half-maximal inhibitory concentration: 15.9 nM
Compound 4: middle estimate off by 2.0-fold (0.30 log units), on the low side; measured number inside the range.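

In this assay, fluoro in place of hydrogen also lowers the number on the propargyloxy core, a 5.0-fold lower number from compound 3 to compound 4 (0.70 log units; beyond the scatter), so the direction carries over but the size does not: the same change on two cores in this assay, a 21-fold lower number (1.32 log units; beyond the scatter) from compound 2 to compound 1 and a 5.0-fold lower number (0.70 log units; beyond the scatter) from compound 3 to compound 4, 4.2-fold (0.62 log units) apart, beyond the scatter of two such steps

Propargyloxy in place of propoxycarbonyl likewise keeps its direction on the fluoro-bearing core, a 5.6-fold lower number from compound 1 to compound 4 (0.75 log units; beyond the scatter), and again the size differs: the same change on two cores in this assay, a 23-fold lower number (1.37 log units; beyond the scatter) from compound 2 to compound 3 and a 5.6-fold lower number (0.75 log units; beyond the scatter) from compound 1 to compound 4, 4.2-fold (0.62 log units) apart, beyond the scatter of two such steps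

For the compounds shown here, each change therefore lowers the number on both cores, but the size of its step depends on the core, so a step measured on one core cannot simply be transferred to another; these four compounds show this for only one pair of changes and do not show why the sizes differ.

The compounds shown leave open whether a chloro or methyl group in the place of the fluoro would also lower the number. They also leave open how the fluoro step would behave with a carboxylic acid or a longer ether chain in the place of the propargyloxy group.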